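One Methyl Fewer on Compound 3

The compounds below may be only part of what the source reports. "The series", "measured", "known", "first", "only" and "open" are said of these compounds alone.

In a physicochemical assay for lipophilicity (on this read-out higher numbers stand for higher lipophilicity and lower numbers for lower lipophilicity), compound 1 (`c1ccc(OCCc2nc3ccccc3[nH]2)cc1`) gives 3.16, compound 2 (`Cc1cc(C)cc(OCc2nc3ccccc3[nH]2)c1`) gives 3.5 and compound 3 (`Cc1ccc(OCc2nc3ccccc3[nH]2)cc1C`) gives 3.4. Compound 3 stands within the usual scatter of both compound 2 and compound 1, so its number sets it apart from neither. Compound 4 (`Cc1cccc(OCc2nc3ccccc3[nH]2)c1`) has not yet been measured. It differs from compound 3 by hydrogen in place of methyl on an aromatic carbon. Among the measured compounds shown here, no two measured compounds differ in one place only, so the data offer no direct guide to this step. In this assay a modest fall, slightly beyond the scatter, is expected, and the estimated step is a number 0.40 log units lower from compound 3 to compound 4 (beyond the scatter). For compound 4 the estimated value is 3, with an expected range from 2.7 to 3.3.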

Compound 4, partition coefficient: 3.14
Beside the measured number, compound 4's estimate is 0.14 log units below it; measured number inside the range.
By their numbers in this assay, from the lowest: compounds 4, 1, 3 and 2 (each within the scatter of the next, the first and the last beyond it).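

In this assay, hydrogen in place of methyl on an aromatic carbon, ortho to a methyl group and para to a large group, gives a number 0.26 log units lower from compound 3 to compound 4 (within the scatter). Among the compounds shown here, a second such replacement gives a number 0.36 log units lower from compound 2 to compound 4 (beyond the scatter), so the loss of one methyl can show in this read-out, although only this second step does so. No evidence at hand bears on these steps.

The compounds shown leave open how an amine or a methoxy group at this place would read. They also leave open whether a chlorine atom would read like methyl.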